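The compounds below may be only part of what the source reports. "The series", "measured", "known", "first", "only" and "open" are said of these compounds alone.

Measured in a functional assay on HeLa cells (Homo sapiens) for cytotoxicity, read by MTT assay, with a stated time of 48 h; a higher number here means a weaker inhibitor, a lower number a stronger inhibitor:
- Compound 1 `C=C1CCC[C@]2(C)CCC(C=O)=CC[C@@]12C`: 191000 nM
- Compound 2 `C=C1CCC[C@]2(C)CCC(c3cn(-c4ccc(C(C)=O)cc4)nn3)=CC[C@@]12C`: 15100 nM
- Compound 3 `C=C1CCC[C@]2(C)CCC(c3cn(CC(=O)Nc4ccc(C)cc4)nn3)=CC[C@@]12C`: 131000 nM

Compound 2 stands lowest of the three, and its gaps to compound 3 and compound 1 both lie beyond the scatter. Compound 4 `C=C1CCC[C@]2(C)CCC(c3cn(-c4cccc(OC)c4)nn3)=CC[C@@]12C`, still unmeasured, carries 3-methoxyphenyl in place of 4-acetylphenyl on an aromatic nitrogen. Going by the values given here, no measured pair isolates this swap, so the expectation is loose. A modest step to a higher number in this assay is expected, near the edge of the scatter, since compound 2 at 15100 nM holds the lowest value, while compound 3, with another group on that nitrogen, gives 131000 nM. Expressed as a change, the estimate is a 2.3-fold higher number from compound 2 to compound 4 (0.37 log units; beyond the scatter). For compound 4 the expected value is 35000 nM, with an estimated range of 11000 nM to 120000 nM.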

Compound 4, half-maximal inhibitory concentration: 27900 nM
Estimate against measurement, compound 4: 1.3-fold (0.10 log units) above; measured number inside the range.
By their numbers in this assay, from the lowest: compounds 2 and 4 (each within the scatter of the next); then compounds 3 and 1 (each within the scatter of the next).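

In this assay, replacing 4-acetylphenyl with 3-methoxyphenyl on the aromatic nitrogen gives a 1.8-fold higher number from compound 2 to compound 4 (0.27 log units; within the scatter), so this position accepts a second aryl group with no change beyond the scatter. In this pair, therefore, the value does not depend on keeping the 4-acetylphenyl group. Nothing available explains this result.

The compounds shown leave open how an amine or a carboxylic acid on this phenyl ring would read in this assay. They also leave open whether a longer chain on that nitrogen would keep this level.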